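A cyclobutylsulfanyl group replaces the fluorinated side chain

A few compounds are considered here, and "the series" means these few. Any claim that something is new, unique, unknown or untested is made for them only; others in the source may bear on it.

Compound 1 `Cc1nc(S(C)(=O)=O)ccc1Oc1ncnc(OC2CCN(C(=O)OC(C)C)CC2)c1F`: 77%
Compound 2 `Cc1nc(S(C)(=O)=O)ccc1Oc1ncnc(OC2CCN(C(=O)O[C@@H](C)CF)CC2)c1F`: 84%
Compound 3 `Cc1nc(S(C)(=O)=O)ccc1Oc1ncnc(OC2CCN(C(=O)SC(C)(C)C)CC2)c1F`: 76%

Of the compounds shown here, three sharing one core have been measured in a functional assay on isolated protein for inhibition of Glucose-dependent insulinotropic receptor (Rattus norvegicus), read by HTRF and cAMP accumulation; a higher number here means a larger maximal response, a lower number a smaller maximal response. Compound 2 gives the highest of the three numbers, yet both of its steps to the others lie within the scatter: a number 7 percentage points higher from compound 1 to compound 2 (within the scatter) and a number 8 percentage points lower from compound 2 to compound 3 (within the scatter). The third step, a number 1 percentage points lower from compound 1 to compound 3 (within the scatter), is likewise within the scatter, so the three compounds cannot be told apart on these numbers.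

Compound 4 `Cc1nc(S(C)(=O)=O)ccc1Oc1ncnc(OC2CCN(C(=O)SC3CCC3)CC2)c1F` is not yet measured. It differs from compound 2 by one change:
a group of 5 heavy atoms (4 carbon, 1 sulfur; one four-membered non-aromatic ring of carbon only) in place of a group of 5 heavy atoms (3 carbon, 1 oxygen, 1 fluorine; no ring), on a carbonyl carbon

Within the data shown here, the step that bears most on this is the one from compound 2 to compound 3, where a sulfur-linked group also replaced the fluorinated chain on the same carbonyl carbon and nothing changed beyond the scatter. The step from compound 1 to compound 3, another exchange on that carbonyl carbon, was equally flat. The expected step of a number 4 percentage points lower from compound 2 to compound 4 (within the scatter) is therefore estimated to stay within the scatter, in no clear direction. Compound 4 is expected to give 80%, with a range from 68% to 92%.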

Compound 4, largest response reached (reported as efficacy), in percent of the reference or control that the assay uses: 81%
Beside the measured number, compound 4's estimate is 1 percentage points below it, within the range that was stated.
By their numbers in this assay, from the lowest: compounds 3, 1, 4 and 2 (each within the scatter of the next).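

In this assay, a sulfur-linked group carrying a ring on this carbonyl carbon cannot be told apart from the open-chain groups, with a number 3 percentage points lower from compound 2 to compound 4 (within the scatter) and a number 4 percentage points higher from compound 1 to compound 4 (within the scatter) both staying within the scatter. Tying the group on the sulfur into a ring gives the same picture, as cyclobutyl in place of tert-butyl yields a number 5 percentage points higher from compound 3 to compound 4 (within the scatter) and this too lies within the scatter. No measurement at hand accounts for these flat steps.

All four compounds lie within the scatter of one another, so these numbers give no ranking of the groups at this position. Going by these compounds, whether a different kind of group on the carbonyl carbon, such as an amine or a longer chain ending in a carboxylic acid, would move the response beyond the scatter remains open.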